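The compounds below may be only part of what the source reports. "The series", "measured", "known", "first", "only" and "open" are said of these compounds alone.

Compound 1 `O=C(Nc1cccc(-n2cc(-c3ccncc3)c(-c3ccc(Cl)c(O)c3)n2)c1)Nc1ccc(Cl)c(Cl)c1`: 8330 nM
Compound 2 `COc1cc(-c2nn(-c3cccc(NC(=O)c4ccc(Cl)c(C(F)(F)F)c4)c3)cc2-c2ccncc2)ccc1Cl`: > 32500 nM

Both compounds were tested in a functional assay on MDA-MB-231 cells (Homo sapiens) for inhibition, read by sulforhodamine B assay, with a stated time of 48 h; on this read-out lower numbers stand for stronger inhibition of growth and higher numbers for weaker inhibition of growth. Compound 1 gives 8330 nM. For compound 2 this assay reports only a limit, > 32500 nM, and not a number. Compound 2 therefore sits at the limit of > 32500 nM in this assay, at which 1 of the 2 values shown sits, which means its growth inhibition is too weak to be pinned down in this assay. Compound 3 `COc1cc(-c2nn(-c3cccc(NC(=O)c4cccc(C(F)(F)F)c4)c3)cc2-c2ccncc2)ccc1Cl` has not been measured yet. It differs from compound 2 in a single place: hydrogen in place of chloro on an aromatic carbon. For the measured compounds named here, no measured step in this assay accompanies this kind of change, so there is nothing to show whether it shifts growth inhibition. In this assay the expected step, a number no higher from compound 2 to compound 3 (the limit leaves the size open), is none beyond the usual scatter. Compound 3 is therefore estimated at 32500 nM, with a range from 9000 nM to 70000 nM, and this assay may again report only a limit for it.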

Compound 3, concentration for total growth inhibition: 9960 nM
For compound 3 the middle estimate is 3.3-fold (0.51 log units) above the measured one; measured number inside the range.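

In this assay, replacing the chloro of the 4-chloro-3-(trifluoromethyl)phenyl group with hydrogen gives an at least 3.2-fold lower number from compound 2 to compound 3 (0.51 log units; beyond the scatter). For the compounds shown here, this is the first sign that this position, ortho to a trifluoromethyl group, affects growth inhibition, and that the chloro there is not required for the measurable inhibition seen with compound 3. The true size of the step stays open, since compound 2 has a limit and not a number: the limit of > 32500 nM in this assay, at which 1 of the 3 values shown sits.

The compounds shown leave open whether a different group at this position, such as fluoro or an amine, would give stronger or weaker growth inhibition than hydrogen. They also leave open what the neighbouring trifluoromethyl group contributes, as it stays unchanged in this pair and no compound shown replaces it with, for example, a nitrile.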